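From Fluoro to Methyl: Will the Numbers Stay Flat?

A few compounds are considered here, and "the series" means these few. Any claim that something is new, unique, unknown or untested is made for them only; others in the source may bear on it.

Of the compounds shown here, three that share one core have been measured in an ADME assay on BHK cells (Mesocricetus auratus) for cytotoxicity, read by MTT assay, with a stated time of 96 h; a lower number here means that less compound is tolerated, a higher number that more compound is tolerated. Compound 1 `FC(F)(F)c1cccc(NC(=S)Nc2ccc(Cl)cc2)c1` gives 10000 nM, compound 2 `O=[N+]([O-])c1ccc(NC(=S)Nc2cccc(C(F)(F)F)c2)cc1` gives 9500 nM, and compound 3 `Fc1ccc(NC(=S)Nc2cccc(C(F)(F)F)c2)cc1Cl` gives 10000 nM. Compound 3 therefore reads the same as compound 1 at the digits reported, and compound 2 lies within the usual scatter of both, so none of the three stands apart.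

The next compound, compound 4 `Cc1ccc(NC(=S)Nc2cccc(C(F)(F)F)c2)cc1Cl`, differs from compound 3 in one place: methyl in place of fluoro on an aromatic carbon. Put simply, this is methyl in place of fluoro on an aromatic carbon, ortho to a chloro group and para to a large group.

Among the compounds with values here, no measured pair makes this exact exchange. Within the data shown here, the only measured step that changes one place is nitro in place of chloro, which gave a 1.1-fold lower number from compound 1 to compound 2 (0.02 log units; within the scatter). That is a different swap and so only an indirect guide, but it stayed within the scatter. On that limited evidence, no step beyond the scatter is expected in this assay. The expected step is a 1.1-fold lower number from compound 3 to compound 4 (0.05 log units; within the scatter). The estimate for compound 4 is 9000 nM, with an expected range of 5000 nM to 15000 nM.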

Compound 4, half-maximal cytotoxic concentration: 10000 nM
Estimate against measurement, compound 4: 1.1-fold (0.05 log units) below, within the range that was stated.
By their numbers in this assay, from the lowest: compounds 2, 1, 3 and 4 (each within the scatter of the next).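

In this assay, methyl in place of fluoro on an aromatic carbon, ortho to a chloro group and para to a large group, gives no change at the digits printed from compound 3 to compound 4 (within the scatter). Among the compounds shown, this is the only direct test of this exchange at this position, and it shows that either group, each of one heavy atom, can occupy this place without the number moving beyond the scatter. Nothing measured here accounts for this flat result, which can be recorded but not explained.

The compounds shown leave open whether a different group in this same place, such as an amine, a carboxylic acid or a longer chain, would also leave the number level. They also leave open whether methyl in place of fluoro would give the same result on a version of the shared core that lacks the chloro group.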